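Pyrimidine in Place of Pyridine on the Amine Nitrogen

A few compounds are considered here, and "the series" means these few. Any claim that something is new, unique, unknown or untested is made for them only; others in the source may bear on it.

Compound 1 `Cc1cccc(NC[C@@H]2CC3(CC3)CN2C(=O)c2nc(C)sc2-c2ccccc2)n1`: 7.6
Compound 2 `O=C(c1cc(Cl)ccc1-c1ncccn1)N1CC2(CC2)C[C@H]1CNc1cc(C(F)(F)F)ccn1`: 7.1
Compound 3 `Cc1ccc(-c2nccs2)c(C(=O)N2CC3(CC3)C[C@H]2CNc2ccc(C(F)(F)F)cn2)n1`: 8

In a functional assay on HEK293 cells for antagonist activity at Orexin receptor type 2 (Homo sapiens), read by FLIPR and calcium flux (on this read-out higher numbers stand for higher potency (the scale is a negative logarithm) and lower numbers for lower potency), compound 1 gives 7.6, the second highest of the three numbers. Compound 3 gives 8, a number higher than compound 1 by more than the usual scatter. Compound 2 gives 7.1, a number lower than compound 1 by more than the scatter. Among the measured compounds shown here, no two of these measured compounds differ in only one place, so no single measured step is available as a guide.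

Compound 4 `Cc1cc(C)nc(NC[C@@H]2CC3(CC3)CN2C(=O)c2nc(C)sc2-c2ccccc2)n1` differs from compound 1 in one place: 4,6-dimethylpyrimidin-2-yl in place of 6-methylpyridin-2-yl on an amine nitrogen. The shared core is kept; the ring on the amine nitrogen gains one ring nitrogen and one methyl. For the measured compounds named here, no measured pair shows a change of this kind, so the size of the step is uncertain, and the estimate is a step of a number 0.20 log units lower from compound 1 to compound 4 (within the scatter), expected to stay within the scatter, with no clear direction. Compound 4 is therefore expected to give 7.4, with a range from 6.8 to 8.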

Compound 4, negative logarithm of the antagonist equilibrium constant: 8.6
Compound 4: middle estimate off by 1.20 log units, on the low side, and the stated range ends below it.
By their numbers in this assay, from the lowest: compound 2; then compound 1; then compound 3; then compound 4.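

In this assay, the ring on the amine nitrogen proves to be a sensitive position: 4,6-dimethylpyrimidin-2-yl in place of 6-methylpyridin-2-yl gives a number 1.00 log units higher from compound 1 to compound 4 (beyond the scatter) and so a gain beyond the scatter. Among the compounds shown here, the earlier compounds could not show this, since none of them differed in only one place, and this is the first measured effect of a single change on the shared core. Nothing available explains the gain.

The step brings in one ring nitrogen and one methyl together, so the compounds shown cannot divide it between them, and a plain pyrimidin-2-yl or a 4,6-dimethylpyridin-2-yl on the same amine nitrogen would be needed to separate the two. As far as these compounds go, whether an ethyl or a methoxy group could take the place of either methyl also remains open.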